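The source may report more compounds than this note shows. Statements on the series, on what has been measured and on what is new or still open speak of the compounds shown alone.

Measured in an ADME assay on microsomes from liver (Homo sapiens) for metabolic stability, read by LC-MS, using NADPH, with a stated time of 45 min, tested at 0.5 uM; on this read-out lower numbers stand for slow clearance and higher numbers for fast clearance:
- compound 1 `O=C(CCSc1ncc(-c2ccccc2)o1)N1CCCC1`: 11 mL/min/g
- compound 2 `O=C(CCSc1nc2cc(Cl)ccc2o1)N1CCC1`: 3.7 mL/min/g
- compound 3 `COc1ccc2oc(SCCC(=O)N3CCCC3)nc2c1`: 6.1 mL/min/g

Compound 2 carries the lowest number of the three in this assay, though compound 3 lies within the scatter of it and only compound 1 stands beyond it. Compound 4 `O=C(CCSc1nc2cc(Cl)ccc2o1)NC1CCCC1` differs from compound 2 in one place: cyclopentylamino in place of azetidin-1-yl on a carbonyl carbon. Among the measured compounds shown here, no pair among the measured compounds isolates this change, so the set gives no direct guide to its size in this assay. A modest move towards faster clearance, beyond the scatter but not far beyond, is expected for the step of a 1.8-fold higher number from compound 2 to compound 4 (0.24 log units; within the scatter). Compound 4 is therefore estimated at 6.5 mL/min/g in this assay, with a range from 3 mL/min/g to 13 mL/min/g.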

Compound 4, intrinsic clearance in a liver preparation (reported as CLH), per the amount of preparation that the assay uses: 11.3 mL/min/g
Beside the measured number, compound 4's estimate is 1.7-fold (0.24 log units) below it; the range from low to high includes it.
By their numbers in this assay, from the lowest: compounds 2, 3, 1 and 4 (each within the scatter of the next, the first and the last beyond it).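

In this assay, among the compounds shown here, the position on the carbonyl carbon proves sensitive to the amine part: cyclopentylamino in place of azetidin-1-yl gives a 3.1-fold higher number from compound 2 to compound 4 (0.48 log units; beyond the scatter), the first single-place step. This one change enlarges the ring and also brings in the amide hydrogen, so the pair cannot separate the two. No supporting measurement bears on the origin of this step.

Going by these compounds, whether the step follows ring size or the amide hydrogen remains open. Piperidin-1-yl and cyclopropylamino on the core of compound 2 would help to separate these two changes.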